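From Dimethylamino to 4-Methylpiperazin-1-yl on the Chain

The source may report more compounds than this note shows. Statements on the series, on what has been measured and on what is new or still open speak of the compounds shown alone.

- compound 1 `COc1ncc(-c2ccc3nc(NC(=O)N4CCCC4)nn3c2)cc1NS(=O)(=O)c1ccc(F)cc1` gives 1290 nM
- compound 2 `COc1ncc(-c2ccc3nc(NC(=O)NCCN(C)C)nn3c2)cc1NS(=O)(=O)c1ccc(F)cc1` gives 220 nM

In a functional assay on HCT-116 cells (Homo sapiens) for cytotoxicity, read by MTT assay, with a stated time of 72 h (on this read-out lower numbers stand for stronger inhibition and higher numbers for weaker inhibition), compound 2 holds the lower of the two measured numbers. Among the measured compounds shown here, the only measured step, a 5.9-fold lower number from compound 1 to compound 2 (0.77 log units; beyond the scatter), came with (2-(dimethylamino)ethyl)amino in place of pyrrolidin-1-yl on a carbonyl carbon. Compound 3 `COc1ncc(-c2ccc3nc(NC(=O)NCCN4CCN(C)CC4)nn3c2)cc1NS(=O)(=O)c1ccc(F)cc1` is the next structure to consider, and its difference is 4-methylpiperazin-1-yl in place of dimethylamino on a saturated chain carbon, two bonds along the chain from an amide-type nitrogen. It carries 4-methylpiperazin-1-yl in place of dimethylamino on a saturated chain carbon, two bonds along the chain from an amide-type nitrogen. For the measured compounds named here, no measured step makes this exact exchange. Going by the values given here, the one measured step bears on it only indirectly, as it shows that changes in this part of the molecule can shift the number. Compound 3 keeps the 2-substituted ethyl chain, so the expected step is only a 1.3-fold higher number from compound 2 to compound 3 (0.10 log units; within the scatter), with no change beyond the scatter anticipated. The estimated value for compound 3 is 280 nM, with an expected range from 100 nM to 800 nM.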

Compound 3, half-maximal inhibitory concentration: 260 nM
The estimate for compound 3 lay 1.1-fold (0.03 log units) above the measured number; low and high end bracket the measured number.
By their numbers in this assay, from the lowest: compounds 2 and 3 (each within the scatter of the next); then compound 1.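

In this assay the exchange of dimethylamino for 4-methylpiperazin-1-yl on a saturated chain carbon, two bonds along the chain from an amide-type nitrogen, gives a 1.2-fold higher number from compound 2 to compound 3 (0.07 log units; within the scatter) and so leaves the number within the scatter, even though the entering group adds a six-membered non-aromatic ring. Set against pyrrolidin-1-yl on a carbonyl carbon, (2-(4-methylpiperazin-1-yl)ethyl)amino gives a 5.0-fold lower number from compound 1 to compound 3 (0.70 log units; beyond the scatter) so the lower number seen earlier with compound 2 is not confined to a dimethylamino chain end. No evidence at hand accounts for either result. The compounds shown leave open whether morpholine at the chain end would keep the number in this range. They also leave open what a longer chain between the amide-type nitrogen and the terminal amine would do.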